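A few compounds are considered here, and "the series" means these few. Any claim that something is new, unique, unknown or untested is made for them only; others in the source may bear on it.

The measured compounds in this study are:

compound 1 `CCN(CC)C(=O)c1cc(-c2ccccc2)c2ccccc2c1`, in an assay on brain with Translocator protein (Rattus norvegicus) as the target (on this read-out lower numbers stand for stronger inhibition and higher numbers for weaker inhibition), compound 1 gives 5 nM
compound 2 `CCOC(=O)c1c(CN(CC)Cc2ccccc2)nc2ccccc2c1-c1ccccc1`, compound 2 gives 700 nM
compound 3 `CCN(Cc1ccccc1)Cc1ccccc1C(=O)N(CC)CC`, compound 3 gives 8210 nM

Among these three, compound 3 stands at the highest number in this assay; compound 2 is the nearest of the other two and compound 1 the furthest from it, and both gaps lie beyond the scatter of repeated measurements. Compound 4 `CCN(Cc1ccccc1)Cc1ccccc1C(=O)N(C)c1ccccc1` has not yet been measured. It differs from compound 3 in one place: methyl(phenyl)amino in place of diethylamino on a carbonyl carbon. Among the measured compounds shown here, no pair of measured compounds here isolates this change, so what it does can only be expected, not read off. Compound 3 sits so far above the other two that the room for a lower number is large, and the change exchanges a small acyclic group for one carrying an aromatic ring. Compound 4 is therefore expected to move toward a lower number, with a step of moderate size, a 3.3-fold lower number from compound 3 to compound 4 (0.52 log units; beyond the scatter). The estimate for compound 4 in this assay is 2500 nM, within a range from 500 nM to 12000 nM.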

Compound 4, half-maximal inhibitory concentration: > 10000 nM
Compound 4 ended at the assay's limit (the forecaster's own chance of this, stated with the estimate: 10%); at least 4.0-fold (0.60 log units) between middle value and limit.
By their numbers in this assay, from the lowest: compound 1; then compound 2; then compound 3. At a limit, above all of these: compound 4.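

Compound 4 gives no number in this assay, only a limit of the assay: the limit of > 10000 nM in this assay, at which 1 of the 4 values shown sits.

Methyl(phenyl)amino in place of diethylamino on a carbonyl carbon gives an at least 1.2-fold higher number from compound 3 to compound 4 (0.08 log units; that floor lies within the scatter), so this change brings no lowering of the number at this position, even though it adds an aromatic ring to a compound with much room to fall. How far compound 4 truly lies past the limit cannot be read, so the size of the step stays undefined and only its floor is known.

The compounds shown leave open whether a smaller group on this carbonyl carbon, such as dimethylamino, or a cyclic amine such as piperidine, would lower the number. They also leave open whether methyl(phenyl)amino would behave the same way on the core of compound 1.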